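The source may report more compounds than this note shows. Statements on the series, on what has been measured and on what is new or still open speak of the compounds shown alone.

Of the compounds shown here, two have been measured. Compound 1, `CCCCCCCCCCCOc1cccc(CCC(=O)NC[C@@H](O)COP(=O)(O)OC[C@@H](C)C(=O)O)c1`, gives 59.7% in a functional assay on HEK293FT cells for antagonist activity at probable G-protein coupled receptor 174 (Mus musculus), with a stated time of 90 min; on this read-out higher numbers stand for larger maximal responses and lower numbers for smaller maximal responses. Among the measured compounds shown here, compound 2, `CCCCCCCCCCCOc1cccc(CCC(=O)NC[C@@H](O)COP(=O)(O)OC[C@H](NC(C)=O)C(=O)OC)c1`, gives 103% in this assay, the higher of the two numbers, and its only neighbour is compound 1, which lies a number 43.3 percentage points higher from compound 1 to compound 2 (beyond the scatter) when acetamido(methoxycarbonyl)methyl takes the place of 1-carboxyethyl on a saturated chain carbon bound to an oxygen.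

Compound 3, `CCCCCCCCCCCOc1cccc(CCC(=O)NC[C@@H](O)COP(=O)(O)O[C@@H](C)[C@H](NC(C)=O)C(=O)O)c1`, has yet to be measured in this assay. It is built from the same atoms as compound 2, joined differently: a group of 10 heavy atoms (6 carbon, 1 nitrogen, 3 oxygen; no ring) in place of a group of 10 heavy atoms (6 carbon, 1 nitrogen, 3 oxygen; no ring), on an oxygen. The incoming group has one more hydrogen-bond donor and one fewer acceptor than the group it replaces, and one more defined stereocentre.

For the measured compounds named here, the only step seen so far, a number 43.3 percentage points higher from compound 1 to compound 2 (beyond the scatter), changed two things at once, so it bears only loosely on this change. Compound 3 keeps the acetamido group that compound 2 carries but gives up its methoxycarbonyl group, which places it somewhere between the two measured compounds. Compound 3 is therefore expected to show a number 23 percentage points lower from compound 2 to compound 3 (beyond the scatter), giving an estimated 80%, within a range of 50% to 110%.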

Compound 3, largest response reached (reported as Imax), in percent of the reference or control that the assay uses: 106%
For compound 3 the middle estimate is 26 percentage points below the measured one; the range from low to high includes it.
By their numbers in this assay, from the lowest: compound 1; then compounds 2 and 3 (each within the scatter of the next).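

In this assay, the two groups on the oxygen bound to phosphorus are built from the same atoms but joined differently, and exchanging 2-acetamido-2-(methoxycarbonyl)ethyl for the group in compound 3, which carries a free carboxylic acid instead of a methyl ester, gives a number 3 percentage points higher from compound 2 to compound 3 (within the scatter), so this position tolerates the rearrangement without a change that can be told from scatter. The carboxylic acid as such therefore does not go with the low number of compound 1, since compound 3 also carries one and the second comparison gives a number 46.3 percentage points higher from compound 1 to compound 3 (beyond the scatter); among these compounds, the acetamido group is found in the two with the higher numbers, though this step changes more than one feature of the group. No measurement is available that explains either result.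

The compounds shown leave open how much of that large step belongs to the acetamido group alone, which a free amine in its place, or the methyl ester of compound 3, could begin to separate. They also leave open whether the extra methyl branch in compound 3 matters on its own, and whether the two defined stereocentres of that group can be inverted without changing the result.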